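From compound 3 to compound 4: a side chain change

A few compounds are considered here, and "the series" means these few. Any claim that something is new, unique, unknown or untested is made for them only; others in the source may bear on it.

Values measured in a functional assay on L1210 cells (Mus musculus) for inhibition (on this read-out higher numbers stand for weaker inhibition and lower numbers for stronger inhibition), are:

Compound 1 `COC1=CC(=O)c2ncnc(NCCCN(C)C)c2C1=O` gives 0.501 ug/mL
Compound 2 `COC(=O)CNc1ncnc2c1C(=O)C(OC)=CC2=O` gives 1.2 ug/mL
Compound 3 `CCN(CC)CCCNc1ncnc2c1C(=O)C(OC)=CC2=O` gives 0.393 ug/mL

Compound 3 at 0.393 ug/mL stands level with compound 1 within the scatter and clear of compound 2 on the other side. The change to compound 4 `COC1=CC(=O)c2ncnc(NCCN(C)C)c2C1=O` is dimethylamino in place of (diethylamino)methyl on a saturated chain carbon, two bonds along the chain from a nitrogen on an aromatic ring and reads as dimethylamino in place of (diethylamino)methyl on a saturated chain carbon, two bonds along the chain from a nitrogen on an aromatic ring. Exchanging dimethylamino for diethylamino alone gave a 1.3-fold lower number from compound 1 to compound 3 (0.11 log units; within the scatter) and so made little difference. The larger steps of a 2.4-fold higher number from compound 1 to compound 2 (0.38 log units; beyond the scatter) and a 3.1-fold lower number from compound 2 to compound 3 (0.48 log units; beyond the scatter) both involve methoxycarbonyl, which compound 4 does not carry. Among the compounds with values here, no measured pair changes the chain length alone, so that part of the change remains open. In this assay no step beyond the scatter is therefore expected, and the expected step is a 1.1-fold higher number from compound 3 to compound 4 (0.06 log units; within the scatter) in size. Compound 4 is estimated at 0.45 ug/mL with an expected range from 0.2 ug/mL to 1 ug/mL in this measurement.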

Compound 4, half-maximal inhibitory concentration: 0.316 ug/mL
Estimate against measurement, compound 4: 1.4-fold (0.15 log units) above, within the range that was stated.
By their numbers in this assay, from the lowest: compounds 4, 3 and 1 (each within the scatter of the next); then compound 2.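

In this assay, the step from the longer to the shorter chain with dimethylamino kept in place can now be read on its own, as a 1.6-fold lower number from compound 1 to compound 4 (0.20 log units; within the scatter), so chain length at this position, open until now, makes no difference beyond the scatter across this pair. The replacement of (diethylamino)methyl by dimethylamino, which alters the chain and the amine together, likewise stays inside the scatter, at a 1.2-fold lower number from compound 3 to compound 4 (0.09 log units; within the scatter). The replacement of methoxycarbonyl gives a 3.8-fold lower number from compound 2 to compound 4 (0.58 log units; beyond the scatter). This places compound 4 with compounds 1 and 3, all clear of the methoxycarbonyl compound 2. No measurement is available to explain why these amine chains read alike.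

The compounds shown leave open how a longer chain ending in dimethylamino would read. They also leave open whether a ring amine such as piperidine or morpholine, or a carboxylic acid in place of methoxycarbonyl, would fall with the amine chains or with compound 2.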